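Swapping an aryl amide substituent and watching cell toxicity

The source may report more compounds than this note shows. Statements on the series, on what has been measured and on what is new or still open speak of the compounds shown alone.

Measured compounds:
compound 1 `O=C(Nc1ccccc1)c1cc2n(n1)CCCN(C(=O)c1ccco1)C2` — "not determined" (no result reported) in an ADME assay on BEAS-2B cells (Homo sapiens) for cytotoxicity, read by fluorescence, with a stated time of 48 h; on this read-out lower numbers stand for higher toxicity in this test and higher numbers for lower toxicity in this test
compound 2 `Cc1ccoc1C(=O)N1CCCn2nc(C(=O)Nc3ccc(F)cc3F)cc2C1` — 5000 nM

Compound 1 has no reported number in this assay, so compound 2 stands alone as the only measured point in the set; in this assay compound 2 gives 5000 nM. For the measured compounds named here, there is no second measured value against which to place it, and no measured step between two compounds is available.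

Compound 3 `Cc1ccoc1C(=O)N1CCCn2nc(C(=O)Nc3ccncn3)cc2C1` is the one still to be tested. It differs from compound 2 in a single place (pyrimidin-4-yl in place of 2,4-difluorophenyl on an amide-type nitrogen). Nothing in the measured data shows how this assay responds to such a change, so any expectation rests on compound 2 alone. The account therefore expects the step from compound 2 to compound 3, a 1.6-fold higher number from compound 2 to compound 3 (0.20 log units; within the scatter), to be small and not clearly beyond the scatter, leaning if anything toward a higher number. For compound 3 in this assay the estimate is 8000 nM, with a range from 3000 nM to 25000 nM.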

Compound 3, half-maximal cytotoxic concentration: 16600 nM
Compound 3: middle estimate off by 2.1-fold (0.32 log units), on the low side; the measured number falls inside the stated range.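

In this assay, for the compounds shown here, placing pyrimidin-4-yl in place of 2,4-difluorophenyl on an amide-type nitrogen gives a 3.3-fold higher number from compound 2 to compound 3 (0.52 log units; beyond the scatter), which is the first measured sign that this assay responds to a change at this position. The direction is toward lower toxicity in this test, and the size is modest, though beyond the usual scatter. The step exchanges a carbon-only aromatic ring bearing two fluorines for a six-membered aromatic ring with 2 hetero atoms and 2 hydrogen-bond acceptors, but no accompanying measurement bears on why the number rises.

This single pair cannot separate the loss of the fluorines from the entry of the ring nitrogens, and compound 1, with no reported result, offers no further comparison at this position. On these data alone, it also remains open how this assay would respond if a pyridin-3-yl group, or an aromatic ring carrying an amine or a carboxylic acid, stood on the same amide-type nitrogen of the shared core, and whether the rise would then continue, stall or reverse.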